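Swapping a Phenyl for a Butyl on a Shared Core

The source may report more compounds than this note shows. Statements on the series, on what has been measured and on what is new or still open speak of the compounds shown alone.

Of the compounds shown here, three built on the same core have been tested in a functional assay on DU-145 cells (Homo sapiens) for cytotoxicity, read by sulforhodamine B assay, with a stated time of 2 days, tested at 100 uM; on this read-out higher numbers stand for more inhibition at the one concentration tested (going by the name of the read-out) and lower numbers for less inhibition. Compound 1 `O=C(Nn1c(-c2cccc([N+](=O)[O-])c2)nc2c(-c3ccc(F)cc3)n[nH]c2c1=O)c1ccccc1` gives 90.8%. Compound 2 `COc1cccc(-c2nc3c(-c4ccco4)n[nH]c3c(=O)n2NC(=O)c2ccccc2)c1` gives 50.5%. Compound 3 `O=C(Nn1c(-c2ccccc2)nc2c(-c3ccc(Cl)cc3)n[nH]c2c1=O)c1ccccc1` gives 90.2%. On these numbers compound 3 stands second of the three: its nearest neighbour is compound 1, whose value lies within the usual scatter of it, so the two cannot be told apart, while compound 2 lies far below it, well beyond the scatter.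

Compound 4 `CCCCc1nc2c(-c3ccc(Cl)cc3)n[nH]c2c(=O)n1NC(=O)c1ccccc1` has not yet been measured. It differs from compound 3 in one place: butyl in place of phenyl on an aromatic carbon. Within the data shown here, no pair among the measured compounds differs in a single place, so nothing shows directly how such a swap affects the read-out; compound 2, the only one far below, differs from the others at more than one position.

A moderate fall is expected, since an aromatic ring gives way to a chain at the aromatic carbon between two ring nitrogen atoms; the step of a number 20.2 percentage points lower from compound 3 to compound 4 (beyond the scatter) is the expected change. Compound 4 is expected to give 70%, with a likely range from 40% to 93%.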

Compound 4, a percentage reported as inhibition, at one concentration (the size of the read-out at that concentration, not a potency): 93.1%
Beside the measured number, compound 4's estimate is 23.1 percentage points below it, and the stated range ends below it.
By their numbers in this assay, from the lowest: compound 2; then compounds 3, 1 and 4 (each within the scatter of the next).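

In this assay the swap gives a number 2.9 percentage points higher from compound 3 to compound 4 (within the scatter) and so the two compounds cannot be told apart. Among these compounds, this is the first direct look at this position: on the shared core, at the aromatic carbon between two ring nitrogen atoms, an open butyl chain reads the same as a phenyl ring. For this one pair, then, an aromatic ring at that carbon is not needed to keep the inhibition seen at the single concentration tested, although that concentration says nothing about potency.

As far as these compounds go, it remains open whether a methyl group, a longer chain, an amine or a carboxylic acid at this carbon would read the same, or whether the result would hold with a group other than the chlorophenyl ring of compound 3 and compound 4 elsewhere on the core. No measurement shown here bears on why butyl and phenyl read alike.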